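This account rests on a few compounds, and the source may have more. Where it says the series, first, only, none or still open, it means among the compounds named here.

In a functional assay on BV-2 cells (Mus musculus) for inhibition, read by Griess assay, with a stated time of 24 h (on this read-out lower numbers stand for stronger inhibition and higher numbers for weaker inhibition), each value below is a limit, not a number:

- compound 1 `CCCc1cc(-c2cc(Br)ccc2OC)no1` gives > 200000 nM
- compound 2 `COc1ccc(Br)cc1-c1cc(CO)on1` gives > 200000 nM
- compound 3 `CCOC(=O)COCc1cc(-c2cc(Br)ccc2OC)no1` gives > 200000 nM

Compound 3 thus has only a limit (> 200000 nM) and no number. The whole set sits there (the limit of > 200000 nM in this assay, at which 3 of the 3 values shown sit). In compound 4 `C=CCOCc1cc(-c2cc(Br)ccc2OC)no1` vinyl takes the place of ethoxycarbonyl on a saturated chain carbon bound to an oxygen on a saturated carbon (vinyl in place of ethoxycarbonyl on a saturated chain carbon bound to an oxygen on a saturated carbon). Neither a step that the two limits leave unreadable from compound 1 to compound 3 nor a step that the two limits leave unreadable from compound 2 to compound 3 has a size that can be read, so both bear on this change without sizing it. Resting on compound 3 and its limit (> 200000 nM), the expectation in this assay is no step beyond the scatter. The estimated step is a number no higher from compound 3 to compound 4 (the limit leaves the size open) with its direction left open. For compound 4 the estimate is 200000 nM within an expected range from 80000 nM to 400000 nM and the result may again be only a limit.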

Compound 4, half-maximal inhibitory concentration: 90400 nM
Compound 4: the middle estimate sits 2.2-fold (0.34 log units) above what was measured; the measured number falls inside the stated range.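

In this assay, this position on the saturated chain carbon bound to an oxygen first gives a readable change: vinyl in place of ethoxycarbonyl brings an at least 2.2-fold lower number from compound 3 to compound 4 (0.34 log units; beyond the scatter). Allyl in place of hydrogen on the oxygen brings an at least 2.2-fold lower number from compound 2 to compound 4 (0.34 log units; beyond the scatter), and allyloxy in place of ethyl brings an at least 2.2-fold lower number from compound 1 to compound 4 (0.34 log units; beyond the scatter). The steps among compound 1, compound 2 and compound 3 cannot be read, and only compound 4 gives a number rather than a limit: the limit of > 200000 nM in this assay, at which 3 of the 4 values shown sit.

From the compounds shown here alone, the full size of each new step stays open, since each starts from a limit. Going by these compounds, whether a longer chain or an amine at this place would lower the number further also stays open.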